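From Phenoxymethyl to 4-(Hydroxymethyl)phenyl on a Triple-Bonded Carbon

The source may report more compounds than this note shows. Statements on the series, on what has been measured and on what is new or still open speak of the compounds shown alone.

Among the measured compounds shown here, in an ADME assay on HepG2 cells (Homo sapiens) for cytotoxicity, read by MTT assay, with a stated time of 72 h (a lower number here means that less compound is tolerated, a higher number that more compound is tolerated), compound 2 `O=[N+]([O-])c1c(CS(=O)(=O)c2ccccc2)nc2c(C#CCOc3ccccc3)cc(Cl)cn12` gives 8400 nM, the only actual number in this small series. Compound 1 `O=[N+]([O-])c1c(CS(=O)(=O)c2ccccc2)nc2c(C#Cc3ccc(F)cc3)cc(Cl)cn12` is reported only as a limit, > 3900 nM. The next structure, compound 3 `O=[N+]([O-])c1c(CS(=O)(=O)c2ccccc2)nc2c(C#Cc3ccc(CO)cc3)cc(Cl)cn12`, differs from compound 2 as follows: 4-(hydroxymethyl)phenyl in place of phenoxymethyl on a triple-bonded carbon. The two have the same atoms, joined differently, with 4-(hydroxymethyl)phenyl in place of phenoxymethyl on a triple-bonded carbon.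

For the measured compounds named here, only one measured step bears on this change. It is a step that the limit leaves unreadable from compound 1 to compound 2, which exchanges 4-fluorophenyl for phenoxymethyl at the same place. It is the reverse kind of exchange, from a substituted phenyl to phenoxymethyl, but it gives no size and no direction. Going by the values given here, the hydroxymethyl group has no measured precedent. Among the compounds with values here, the expectation therefore stays close to the one available number, and no shift beyond the scatter is predicted. The expected change is a 1.2-fold lower number from compound 2 to compound 3 (0.08 log units; within the scatter), with either direction remaining possible. For compound 3 the estimated value is 7000 nM, with an expected range from 2500 nM to 20000 nM.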

Compound 3, half-maximal cytotoxic concentration: > 15600 nM
Compound 3 ended at the assay's limit (the forecaster's own chance of this, stated with the estimate: 35%); middle value at least 2.2-fold (0.34 log units) from the limit.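

In this assay, compound 3 gives > 15600 nM, which is a limit of the assay and not a number. Putting 4-(hydroxymethyl)phenyl in place of phenoxymethyl on the triple-bonded carbon yields the first step at this place that can be read at all, as an at least 1.8-fold higher number from compound 2 to compound 3 (0.26 log units; that floor lies within the scatter), so this change is not shown to go beyond the usual scatter, although the true size may be larger. The steps from compound 1 cannot be read, and the step to compound 3 has only a floor, which is set by a limit: the limit of > 15600 nM in this assay, at which 1 of the 3 values shown sits.

On these data alone, whether hydroxymethyl and fluoro differ on the aromatic carbon stays open, as compound 1 and compound 3 are both known only as limits, so neither can be ranked against the other. As far as these compounds go, how an amine or a carboxylic acid in place of the hydroxymethyl would read remains open as well, as does the actual value of compound 3 beyond its limit.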